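Benzyloxycarbonyl to carboxy: compound 2 to compound 3

A few compounds are considered here, and "the series" means these few. Any claim that something is new, unique, unknown or untested is made for them only; others in the source may bear on it.

Two compounds of the series have been run in a functional assay on the whole organism (Tail, strain ICR) with Mus musculus as the target, in the tail flick test, with a stated time of 30 min, at a dose of 25 umol/kg by the oral route; a higher number here means a stronger effect of the compound at the dose given, a lower number a weaker effect:

compound 1, `O=C(CN(c1nc(Cl)nc2[nH]cnc12)C1CC1)N[C@@H](CO)C(=O)O`: 38.7%
compound 2, `NC(=O)CC[C@H](NC(=O)CN(c1nc(Cl)nc2[nH]cnc12)C1CC1)C(=O)OCc1ccccc1`: 30.8%

Compound 2 and compound 1 lie within the scatter of each other in this assay, so the two numbers do not separate them; compound 2 is simply one of two values that sit close together. Within the data shown here, no step between compounds differing in one place is available, so nothing about the effect of any single change has been measured directly.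

Compound 3, `NC(=O)CC[C@H](NC(=O)CN(c1nc(Cl)nc2[nH]cnc12)C1CC1)C(=O)O`, is not yet measured. It arises from compound 2 by hydrogen in place of benzyl on an oxygen next to a carbonyl group. In compound 1 the same carboxy end is present and compound 1 gives 38.7%, a number not separable from that of compound 2; this gives no sign that the benzyl group matters beyond the scatter.

The step from compound 2 to compound 3 is therefore expected to be small, with no clear direction: a number 5.2 percentage points higher from compound 2 to compound 3 (within the scatter). Compound 3 is expected to give 36%, with a range from 22% to 50%.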

Compound 3, a percentage reported as activity, at one dose (the size of the read-out at that dose, not a potency): 33.1%
Estimate against measurement, compound 3: 2.9 percentage points above; low and high end bracket the measured number.
By their numbers in this assay, from the lowest: compounds 2, 3 and 1 (each within the scatter of the next).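

Among these compounds, with hydrogen in place of benzyl on an oxygen next to a carbonyl group, this assay shows a number 2.3 percentage points higher from compound 2 to compound 3 (within the scatter) as the first directly measured step at this position, so the benzyloxycarbonyl and carboxy ends are not separated at this dose. The side chain now has a measured step as well: carbamoylmethyl in place of hydroxy on a saturated chain carbon, two bonds along the chain from an amide-type nitrogen and a carbonyl carbon, gives a number 5.6 percentage points lower from compound 1 to compound 3 (within the scatter) and is likewise not separated, so neither change in the series reads beyond the scatter. No measurement at hand accounts for these readings.

As far as these compounds go, it remains open whether any replacement at these two places would separate from the scatter, for example a methyl ester in place of the benzyl ester, or an amine or a longer alkyl chain in place of carbamoylmethyl. All three readings also come from a single dose and a single time in this assay and leave open how the compounds compare at other doses or times.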